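From bromo to hydroxy in a growth inhibition series

The source may hold more compounds than are shown below. What is called first, only, known or untested is meant among the compounds shown, and "the series" means these compounds.

Of the compounds shown here, two that share one core have been measured in a functional assay on NCI-H1299 cells (Homo sapiens) for inhibition, read by CCK-8 assay, with a stated time of 72 h, tested at 10 uM; a higher number here means more inhibition of growth at the concentration tested, a lower number less inhibition of growth. Compound 1 (`CN(C)C(=O)c1cc2cnc(Nc3ccc(NC(=O)C4(C(=O)Nc5ccccc5F)CC4)cc3)nc2n1C1CCCC1`) gives 89.6%, and compound 2 (`CN(C)C(=O)c1cc2cnc(Nc3ccc(NC(=O)C4(C(=O)Nc5ccc(Br)cc5)CC4)cc3)nc2n1C1CCCC1`) gives 76.9%, which makes compound 2 the lower of the two. Compound 3 (`CN(C)C(=O)c1cc2cnc(Nc3ccc(NC(=O)C4(C(=O)Nc5ccc(O)cc5)CC4)cc3)nc2n1C1CCCC1`) keeps all of compound 2 except one group: hydroxy in place of bromo on an aromatic carbon. Hydroxy takes the place of bromo on an aromatic carbon, para to a large group.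

Among the compounds with values here, only one measured step bears on this change: a number 12.7 percentage points lower from compound 1 to compound 2 (beyond the scatter). That modest step also alters the aromatic ring on the amide-type nitrogen, so changes on this ring can move the result in this assay. Within the data shown here, it compares a different pair of groups, however, and no measured compound carries a hydroxy, so it gives no firm direction here. A step of comparable or smaller size is the reasonable expectation. The expected step, a number 3.1 percentage points higher from compound 2 to compound 3 (within the scatter), is a small one that may not rise beyond the scatter. For compound 3 the estimated value is 80%, with an expected range from 62% to 92%.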

Compound 3, percent growth inhibition at one concentration: 89.7%
Compound 3: the middle estimate sits 9.7 percentage points below what was measured, and the stated range covers the measured number.
By their numbers in this assay, from the lowest: compound 2; then compounds 1 and 3 (each within the scatter of the next).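

In this assay, putting hydroxy in place of bromo on the aromatic carbon para to a large group gives a number 12.8 percentage points higher from compound 2 to compound 3 (beyond the scatter) and so shows that this one group, changed alone, can move the result. The earlier step could not show this, since it changed both the substituent and its place on the ring. The second new step, a number 0.1 percentage points higher from compound 1 to compound 3 (within the scatter), puts the 4-hydroxyphenyl group and the 2-fluorophenyl group level in this assay, which leaves compound 2, with its 4-bromophenyl group, as the one of the three that stands apart, and nothing measured here explains why bromo and hydroxy differ.

The compounds shown leave open whether the higher reading is particular to hydroxy, or whether an amine, a methoxy group or a carboxylic acid at the same position would give a similar number. They also leave open whether compound 1 and compound 3 would still read alike at other concentrations, since each reading here comes from a single concentration.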